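A few compounds are considered here, and "the series" means these few. Any claim that something is new, unique, unknown or untested is made for them only; others in the source may bear on it.

Measured so far:
Compound 1, `Cn1c(CCc2nccs2)nc2cc(Cl)c(Cl)cc21`: 16000 nM
Compound 2, `Cn1c(CCc2ccco2)nc2cc(Cl)c(Cl)cc21`: 5900 nM

Within the data shown here, in a functional assay on HepG2 cells (Homo sapiens) for cytotoxicity (on this read-out lower numbers stand for higher toxicity in this test and higher numbers for lower toxicity in this test), compound 2 gives 5900 nM, the lower of the two numbers so far; its only neighbour is compound 1, and the step of a 2.7-fold lower number from compound 1 to compound 2 (0.43 log units; beyond the scatter) separates them. Compound 3, `Cn1c(CCc2ccncc2)nc2cc(Cl)c(Cl)cc21`, has not yet been measured. It differs from compound 2 in one place: pyridin-4-yl in place of furan-2-yl on a saturated chain carbon, two bonds along the chain from an aromatic carbon. Among the measured compounds shown here, only one measured step bears on a change of this kind, the swap of one small aromatic ring for another on the same chain carbon. That step, a 2.7-fold lower number from compound 1 to compound 2 (0.43 log units; beyond the scatter), was modest, and it concerned two five-membered rings, whereas here a six-membered ring enters, so it is only a loose guide. For the measured compounds named here, the counted difference shows the leaving and entering rings alike in hydrogen-bond donors and acceptors, and nothing among the measured compounds points to a large shift in either direction. A step of roughly the size already seen, in either direction, is the most that can be expected in this assay. For compound 3 the estimate is 8000 nM, within the range 3000 nM to 25000 nM. The expected step is therefore a 1.4-fold higher number from compound 2 to compound 3 (0.13 log units; within the scatter).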

Compound 3, half-maximal cytotoxic concentration: 35800 nM
Compound 3: the middle estimate sits 4.5-fold (0.65 log units) below what was measured; the measured number lies above the stated range.
By their numbers in this assay, from the lowest: compound 2; then compound 1; then compound 3.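

In this assay, the ring on this saturated chain carbon can move the number further than the first pair suggested: pyridin-4-yl in place of furan-2-yl gives a 6.1-fold higher number from compound 2 to compound 3 (0.78 log units; beyond the scatter), and pyridin-4-yl in place of 1,3-thiazol-2-yl gives a 2.2-fold higher number from compound 1 to compound 3 (0.35 log units; beyond the scatter). Both steps are beyond the usual scatter, so compound 3 has the highest number of the three and shows the lowest toxicity in this test. The counts do not separate furan-2-yl from pyridin-4-yl, since both have no hydrogen-bond donors, one acceptor and no net charge, although the rings differ in size and in their hetero atom; no measurement here explains why the numbers differ.

The compounds shown leave open whether the higher number goes with the six-membered ring itself or with its ring nitrogen, a question on which a plain phenyl ring at the same place would bear. They also leave open whether the same order of rings would hold on a longer chain, and what an amine would do in place of the ring.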